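This account rests on a few compounds, and the source may have more. Where it says the series, first, only, none or still open, it means among the compounds named here.

Compound 2, `COc1cccc(Oc2ccc3c(NCCCNCc4ccco4)ccnc3c2)c1`, gives 317 10^-6 cm/s in an ADME assay for permeability, using PAMPA, with a stated time of 30 min, at pH 7.4; a lower number here means that the compound crosses the layer more slowly, a higher number that the compound crosses the layer faster. Its nearest measured neighbour, compound 1, `COc1cccc(Oc2ccc3c(NCCCNCc4cc(F)ccc4OC)ccnc3c2)c1`, gives 317 10^-6 cm/s in this assay, and the step of no change at the digits printed from compound 1 to compound 2 (within the scatter) shows no change beyond the scatter when furan-2-yl replaces 5-fluoro-2-methoxyphenyl on a saturated chain carbon bound to an amine nitrogen. Compound 2 thus stands level with compound 1 at the top of the measured range.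

Compound 3, `Clc1ccc(Oc2ccc3c(NCCCNCc4ccco4)ccnc3c2)cc1`, differs from compound 2 by 4-chlorophenyl in place of 3-methoxyphenyl on an oxygen on an aromatic ring. Going by the values given here, no measured step touches this oxygen on an aromatic ring, so the one known step gives only indirect guidance: it shows that changing an aromatic group elsewhere left this assay unmoved. A change leaving no hydrogen-bond acceptor in place of one is not expected to alter this picture beyond the scatter, so the expected step of a 1.1-fold lower number from compound 2 to compound 3 (0.02 log units; within the scatter) is small. Compound 3 is therefore estimated at 300 10^-6 cm/s, with a range from 150 10^-6 cm/s to 600 10^-6 cm/s.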

Compound 3, apparent permeability: 317 10^-6 cm/s
Compound 3: the middle estimate sits 1.1-fold (0.02 log units) below what was measured; low and high end bracket the measured number.
By their numbers in this assay, from the lowest: compounds 1, 2 and 3 (each within the scatter of the next).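

In this assay, 4-chlorophenyl in place of 3-methoxyphenyl on an oxygen on an aromatic ring gives no change at the digits printed from compound 2 to compound 3 (within the scatter). Going by these compounds alone, this is the first measured step at this position, and it shows that the read-out stays within the scatter here even though the entering group counts no hydrogen-bond acceptor and the leaving group counts one; together with no change at the digits printed from compound 1 to compound 2 (within the scatter), it means that neither of the two places changed so far has moved the number beyond the scatter. Nothing available here explains this flat result.

From the compounds shown here alone, it remains open whether the number would hold with an amine or a carboxylic acid on the phenyl ring bound to this oxygen. A longer chain carrying the furan-2-yl group is equally untested in the compounds shown, so the reach of this flat picture is unknown.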